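A few compounds are considered here, and "the series" means these few. Any claim that something is new, unique, unknown or untested is made for them only; others in the source may bear on it.

In a functional assay on the whole organism (strain C57BL/6) for inhibition, with Mus musculus as the target, read by microscopy, with a stated time of 6 days, at a dose of 10 mg/kg by the oral route (a lower number here means less inhibition, a higher number more inhibition at the dose given (going by the name of the read-out)), the three measured compounds span a wide range. Compound 1 `CNCc1cc(Oc2ccc3c(ccn3C(=O)Nc3cccc(C(F)(F)F)c3)c2)ncn1` gives 67%, compound 3 `CCN1CCc2c(ncnc2Oc2ccc3c(ccn3C(=O)Nc3cccc(C(F)(F)F)c3)c2)C1` gives 81%, and compound 2 `O=C(Nc1cccc(C(F)(F)F)c1)n1ccc2cc(Oc3ncnc4c3CNCC4)ccc21` gives 0%, the lowest of the three, sitting beyond the scatter below both of the others. Going by the values given here, the one step recorded into compound 2 is a number 67 percentage points lower from compound 1 to compound 2 (beyond the scatter), a large fall that came with the fused ring replacing the open chain on the oxygen on the aromatic ring.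

Compound 4 `C[C@@H]1NCc2ncnc(Oc3ccc4c(ccn4C(=O)Nc4cccc(C(F)(F)F)c4)c3)c21` has the same atoms as compound 2, joined differently: a group of 10 heavy atoms (7 carbon, 3 nitrogen; one five-membered non-aromatic ring with 1 hetero atom, one six-membered aromatic ring with 2 hetero atoms) in place of a group of 10 heavy atoms (7 carbon, 3 nitrogen; one six-membered non-aromatic ring with 1 hetero atom, one six-membered aromatic ring with 2 hetero atoms), on an oxygen on an aromatic ring. Among the compounds with values here, no measured step bears directly on a five-membered fused ring at this place. Within the data shown here, the only step at this position, from compound 1 to compound 2, was large and downward, while compound 3 shows that a fused six-membered ring carrying an ethyl group can still give a high value. The expectation for compound 4 is therefore an upward move of moderate size, a number 35 percentage points higher from compound 2 to compound 4 (beyond the scatter), with low confidence. Compound 4 is estimated at 35%, within a range from 0% to 80%.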

Compound 4, a percentage reported as inhibition, in the whole organism at one dose (the size of the read-out at that dose, not a potency): 41%
For compound 4 the middle estimate is 6 percentage points below the measured one; low and high end bracket the measured number.
By their numbers in this assay, from the lowest: compound 2; then compound 4; then compound 1; then compound 3.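

In this assay, the fall seen with compound 2 does not extend to every fused group on this oxygen: a number 41 percentage points higher from compound 2 to compound 4 (beyond the scatter). The same atoms, joined as a five-membered non-aromatic ring instead of a six-membered one, thus give a clearly different reading at this place. The open-chain group keeps an edge over this fused group, a number 26 percentage points lower from compound 1 to compound 4 (beyond the scatter), and nothing among the data given explains either step.

Whether the defined stereocentre of compound 4 matters remains open, as its mirror-image form is not among the compounds shown. Also open, as far as these compounds go, is how the five-membered fused group would read with a longer chain such as a propyl group, or with a carboxylic acid, on that ring.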